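The source may hold more compounds than are shown below. What is called first, only, known or untested is meant among the compounds shown, and "the series" means these compounds.

Measured so far in an assay on isolated protein for inhibition of protein phosphatase 1D (Homo sapiens), read by malachite green; on this read-out higher numbers stand for weaker inhibition and lower numbers for stronger inhibition:

- compound 1 `O=c1[nH]c2ccc(-c3csc(-c4ccc(Cl)cc4)n3)cc2o1`: < 20000 nM, a limit of the assay rather than a number.
- compound 2 `O=c1[nH]c2ccc(-c3csc(-c4ccc(F)c(F)c4)n3)cc2o1`: < 20000 nM, again a limit of the assay.

Compound 2 therefore stands at the same limit as the only other compound shown; the two values set no order between them (the limit of < 20000 nM in this assay, at which 2 of the 2 values shown sit). Among the compounds with values here, no step between measured compounds is available.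

Compound 3 `O=c1[nH]c2ccc(-c3csc(-c4ccc(F)c(O)c4)n3)cc2o1` follows from compound 2 by hydroxy in place of fluoro on an aromatic carbon. With both known values sitting at a limit, the expected step in this assay from compound 2 to compound 3 is estimated as a step that the limit leaves unreadable from compound 2 to compound 3, with no direction beyond the scatter claimed. Compound 3 is expected at about 5000 nM, between 800 nM and 20000 nM.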

Compound 3, half-maximal inhibitory concentration: < 20000 nM
Compound 3: no number, only a limit; the forecaster's own chance of this, stated with the estimate: 50%; the middle value is on the limit's open side.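

No step from compound 2 to compound 3 can be read, as both values are limits of the assay: the limit of < 20000 nM in this assay, at which 3 of the 3 values shown sit.

The compounds shown leave open how potent each one actually is, and whether hydroxy in place of fluoro changes potency at all.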